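Chloro for Trifluoromethyl on the Fused Ring of Compound 2

The compounds below may be only part of what the source reports. "The series", "measured", "known", "first", "only" and "open" are said of these compounds alone.

Measured compounds:
compound 1 `O=C(Nc1ccc(-n2ncc3c(C(F)(F)F)cccc32)cc1)Nc1ccc(Cl)c(C(F)(F)F)c1` — 8000 nM
compound 2 `O=C(Nc1ccc(-n2ncc3c(C(F)(F)F)cccc32)cc1)Nc1ccc(C(F)(F)F)cc1` — 1000 nM

In a functional assay on HepG2 cells (Homo sapiens) for cytotoxicity, read by MTT assay, with a stated time of 72 h (on this read-out higher numbers stand for weaker inhibition and lower numbers for stronger inhibition), compound 1 gives 8000 nM and compound 2 gives 1000 nM. Going by the values given here, compound 2 holds the lowest number of the two measured compounds; the only measured step is an 8.0-fold lower number from compound 1 to compound 2 (0.90 log units; beyond the scatter), and it concerns the aryl ring on the amide-type nitrogen. Among the compounds with values here, compound 3 `O=C(Nc1ccc(-n2ncc3c(Cl)cccc32)cc1)Nc1ccc(C(F)(F)F)cc1` differs from compound 2 by chloro in place of trifluoromethyl on an aromatic carbon, a change on the shared core at a place no measured step touches. Within the data shown here, there is thus no direct precedent here for the exchange. With nothing to point either way, compound 3 is expected to stay close to compound 2 in this assay, with any step within the usual scatter or only a little beyond it. Compound 3 is therefore estimated at 1500 nM, with a range of 500 nM to 5000 nM. That estimate amounts to an expected 1.5-fold higher number from compound 2 to compound 3 (0.18 log units; within the scatter).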

Compound 3, half-maximal inhibitory concentration: 6700 nM
Beside the measured number, compound 3's estimate is 4.5-fold (0.65 log units) below it; the measured number lies above the stated range.
By their numbers in this assay, from the lowest: compound 2; then compounds 3 and 1 (each within the scatter of the next).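

On this aromatic carbon, ortho to a fused ring and meta to a fused ring, chloro in place of trifluoromethyl in this assay gives a 6.7-fold higher number from compound 2 to compound 3 (0.83 log units; beyond the scatter) and so moves the number beyond the scatter. The earlier step concerned only the aryl ring on the amide-type nitrogen, whereas this one shows that the number also responds to a change on the shared core, with trifluoromethyl holding the lower number of this pair. Nothing available explains this step.

The compounds shown leave open whether another group on this carbon, such as a nitrile, a methoxy group or an amine, would stay near compound 2 or move further from it. On these data alone, it also remains open whether the step would keep its size with the 4-chloro-3-(trifluoromethyl)phenyl group of compound 1 on the amide-type nitrogen.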